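Chalcone series with a substituted pyrazolone-type aryl: chloro to hydrogen

The source may report more compounds than this note shows. Statements on the series, on what has been measured and on what is new or still open speak of the compounds shown alone.

Measured so far:
compound 1, `COc1cc(/C=C/C(=O)c2cccc(-n3cc(-c4ccc(Cl)cc4)[nH]c3=O)c2)cc(OC)c1OC`: 3220 nM
compound 2, `COc1cc(/C=C/C(=O)c2cccc(-n3cc(-c4ccccc4)[nH]c3=O)c2)ccc1O`: 2270 nM

In a functional assay on RXF 393 cells (Homo sapiens) for inhibition (a higher number here means a weaker inhibitor of growth, a lower number a stronger inhibitor of growth), compound 1 gives 3220 nM and stands at the highest of the two numbers; in this assay compound 2 gives 2270 nM, and the gap between the two lies within the scatter, so no order can be read from them. Among the measured compounds shown here, the two compounds differ in more than one place, so no single step is defined between them.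

Compound 3, `COc1cc(/C=C/C(=O)c2cccc(-n3cc(-c4ccccc4)[nH]c3=O)c2)cc(OC)c1OC`, is not yet measured. It differs from compound 1 by hydrogen in place of chloro on an aromatic carbon.

For the measured compounds named here, no measured pair shows this change on its own. The remainder of the structure is unchanged, and compound 2, which also carries a phenyl without the chloro, sits near compound 1. The step from compound 1 to compound 3 is therefore expected to be small, a 1.1-fold lower number from compound 1 to compound 3 (0.03 log units; within the scatter), with no direction that goes beyond the scatter. Compound 3 is estimated at 3000 nM in this assay, with a range from 1400 nM to 6500 nM.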

Compound 3, concentration for 50% growth inhibition: 1710 nM
Estimate against measurement, compound 3: 1.8-fold (0.24 log units) above, within the range that was stated.
By their numbers in this assay, from the lowest: compounds 3, 2 and 1 (each within the scatter of the next).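

In this assay, the change from 4-chlorophenyl to phenyl now has a step of its own (a 1.9-fold lower number from compound 1 to compound 3 (0.27 log units; within the scatter)), so this pair shows that the chloro, on an aromatic carbon para to a large group, can be replaced by hydrogen without a shift beyond the scatter. The pair gives no direction for this change, and it rests on the core of compound 1 alone. Nothing at hand offers a reason for the size of this step.

Still open, on these data alone, is whether an amine, a carboxylic acid or a nitrile at this same place would give a step beyond the scatter. Also open, as far as these compounds go, is whether adding a chloro at this place on the core of compound 2 would give a step of similar size.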